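Bromo for benzoyl at a limit of the cytotoxicity read-out

The source may hold more compounds than are shown below. What is called first, only, known or untested is meant among the compounds shown, and "the series" means these compounds.

In an ADME assay on HEK-293T cells (Homo sapiens) for cytotoxicity, read by luminescence, with a stated time of 24 h (on this read-out higher numbers stand for lower toxicity in this test and lower numbers for higher toxicity in this test), compound 1 (`COc1ccc(Cn2c(C(=O)N3CCCCC3)cc3sccc32)cc1`) gives > 100000 nM as a limit of the assay and not a number. Compound 2 (`CCCNC(=O)C1CCN(C(=O)c2cc3sc(C(=O)c4ccccc4)cc3n2Cc2ccc(OC)cc2)CC1`) gives > 100000 nM in this assay and this too is only a limit. The record so far is therefore the limit of > 100000 nM in this assay, at which 2 of the 2 values shown sit, and it holds no measured number for either compound.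

Compound 3 (`CCCNC(=O)C1CCN(C(=O)c2cc3sc(Br)cc3n2Cc2ccc(OC)cc2)CC1`) has not yet been measured. It carries bromo in place of benzoyl on an aromatic carbon of a five-membered aromatic ring with 1 sulfur, next to the ring sulfur, and the change is counted as bromo in place of benzoyl on an aromatic carbon in full. For the measured compounds named here, no measured pair in this small set shows what such a change does.

With compound 2 at > 100000 nM as a limit, no step beyond the scatter is expected in this assay and no direction is favoured. The expected step of a number no higher from compound 2 to compound 3 (the limit leaves the size open) is an estimate that stays within the scatter. In this assay the estimated value for compound 3 is 100000 nM with an expected range from 40000 nM to 200000 nM and a report as a limit is again the likeliest outcome.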

Compound 3, half-maximal cytotoxic concentration: > 100000 nM
Compound 3: only a limit was reported (the forecaster's own chance of this, stated with the estimate: 75%); the middle value lies on the limit itself.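

For the compounds shown here, compound 2 and compound 3 are both reported only as limits in this assay, and no step between them can be read for bromo in place of benzoyl on an aromatic carbon. The record stands at a single limit: the limit of > 100000 nM in this assay, at which 3 of the 3 values shown sit.

The compounds shown leave open what half-maximal cytotoxic concentration any of them would give as a measured number.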